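Cytotoxicity on MT4 cells across a thiophene-amide series

The source may hold more compounds than are shown below. What is called first, only, known or untested is meant among the compounds shown, and "the series" means these compounds.

Measured so far:
compound 1 `CC1CC=C(C(=O)N(c2cc(C#CC(C)(C)C)sc2C(=O)O)C(C)C)CC1`: > 20000 nM
compound 2 `CC(C)(C)C#Cc1cc(N(C(=O)[C@H]2CC[C@H](C)CC2)[C@H]2CC[C@@](O)(CO[C@H]3CCOC3)CC2)c(C(=O)O)s1`: > 20000 nM
compound 3 `CC(C)(C)C#Cc1cc(N(C(=O)[C@H]2CC[C@H](C)CC2)[C@H]2C[C@@H](Oc3cccnc3)C2)c(C(=O)O)s1`: > 20000 nM

In an ADME assay on MT4 cells (Homo sapiens) for cytotoxicity, with a stated time of 5 days (a lower number here means that less compound is tolerated, a higher number that more compound is tolerated), compound 3 reaches only a limit, not a number. The same holds for compound 1 and compound 2, so all three values shown sit at the limit of this assay (the limit of > 20000 nM in this assay, at which 3 of the 3 values shown sit); no ordering among them can be read. Compound 4 `CC(C)(C)C#Cc1cc(N(CCO)C(=O)[C@H]2CC[C@H](C)CC2)c(C(=O)O)s1` is not yet measured. Its difference from compound 3 is 2-hydroxyethyl in place of 3-((pyridin-3-yl)oxy)cyclobutyl on an amide-type nitrogen. For the measured compounds named here, since no step between measured compounds is known here, no size can be drawn from the data; the expectation is for no step beyond the scatter in this assay, with compound 4 again likely to come in at the limit. The estimate for compound 4 in this assay is 30000 nM (range 15000 nM to 80000 nM), an expected step that the limit leaves unreadable from compound 3 to compound 4.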

Compound 4, half-maximal cytotoxic concentration: > 20000 nM
Compound 4: only a limit was reported; the forecaster's own chance of this, stated with the estimate: 80%; the middle value is on the limit's open side.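

For the compounds shown here, no step from compound 3 to compound 4 can be read in this assay, as both compounds end at a limit: the limit of > 20000 nM in this assay, at which 4 of the 4 values shown sit.
Still open is where any compound shown would give a numerical value in this assay.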